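Halogen change on a cyclohexyl oxadiazole series

A few compounds are considered here, and "the series" means these few. Any claim that something is new, unique, unknown or untested is made for them only; others in the source may bear on it.

Three compounds have numbers in an ADME assay on RAW264.7 cells (Mus musculus) for cytotoxicity, read by MTT assay, with a stated time of 48 h; on this read-out higher numbers stand for lower toxicity in this test and lower numbers for higher toxicity in this test. Compound 1 `C#CCN(c1nc(-c2cccc(Br)c2)no1)C1CCCCC1` gives 31.8 ug/mL. Compound 3 `C#CCOc1ccc(-c2noc(NC3CCCCC3)n2)cc1` gives 38.3 ug/mL, and compound 2 `CC(=O)OC[C@H]1O[C@H](OC[C@H](Cn2cc(-c3ccc(-c4noc(NC5CCCCC5)n4)cc3)nn2)OC(C)=O)C=C[C@@H]1OC(C)=O` gives 16.3 ug/mL. Compound 1 stands second highest of the three; its gap to compound 3 and its gap to compound 2 both lie within the scatter, so no order among them can be claimed from these numbers.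

Compound 4 `C#CCN(c1nc(-c2ccc(Cl)cc2)no1)C1CCCCC1` has not been measured in this assay. It differs from compound 1 in one place: 4-chlorophenyl in place of 3-bromophenyl on an aromatic carbon. Among the compounds with values here, no pair of measured compounds differing only in this way is available, so the effect of this change is not known from the series itself. All three measured values fall close together, which gives no sign that a change of this kind would move the number far. The step of a 1.1-fold lower number from compound 1 to compound 4 (0.03 log units; within the scatter) is therefore expected to stay within the scatter, in either direction or none. Compound 4 is estimated at 30 ug/mL in this assay, with a range from 15 ug/mL to 60 ug/mL.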

Compound 4, half-maximal cytotoxic concentration: 15.1 ug/mL
Compound 4: the middle estimate sits 2.0-fold (0.30 log units) above what was measured; measured number inside the range.
By their numbers in this assay, from the lowest: compounds 4, 2, 1 and 3 (each within the scatter of the next, the first and the last beyond it).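

In this assay, this position on the shared core responds to a change of aryl group: 4-chlorophenyl in place of 3-bromophenyl gives a 2.1-fold lower number from compound 1 to compound 4 (0.32 log units; beyond the scatter), a modest step. The two groups match in heavy-atom count, hydrogen-bond donors, hydrogen-bond acceptors and net charge, so the number moves even though none of these counts changes. No measurement available here accounts for the step.

The change swaps the halogen and its place on the phenyl ring together, so a single pair cannot say which of the two goes with the step. A plain phenyl group at this position would show whether the halogen matters at all, and an aminophenyl group would test a substituent of a different kind.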